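Methyl on the Aromatic Ring of a Weak Modulator

A few compounds are considered here, and "the series" means these few. Any claim that something is new, unique, unknown or untested is made for them only; others in the source may bear on it.

Compound 1, `CCNc1ncc(C#Cc2ccccc2)cn1`: "not active" (no number reported)
Compound 2, `CCc1ncc(C#Cc2ccc(C)cc2)cn1`: "not active" (no number reported)
Compound 3, `CC(C)(C)c1ncc(C#Cc2ccccc2)cn1`: 247000 nM

These three compounds were tested in an assay on HEK293 cells for positive allosteric modulation of metabotropic glutamate receptor 5 (Rattus norvegicus); on this read-out higher numbers stand for an effect only at larger amounts of compound and lower numbers for an effect already at smaller amounts. Compound 1 and compound 2 yielded no number. Within the data shown here, compound 3 is the only one with a value, and that value is very weak. Compound 4, `Cc1ccc(C#Cc2cnc(C(C)(C)C)nc2)cc1`, has not yet been measured. It differs from compound 3 by methyl in place of hydrogen on an aromatic carbon. Among the measured compounds shown here, no measured pair shows this change, so no step is known for it, and a step of no more than the usual scatter is expected in this assay, in either direction. Compound 4 is estimated at 150000 nM, within 50000 nM to 450000 nM. That estimate means an expected step of a 1.6-fold lower number from compound 3 to compound 4 (0.22 log units; within the scatter).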

Compound 4, half-maximal effective concentration: "not active" (no number reported)
Nothing numeric was reported for compound 4; no gap can be computed for the estimate.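

Among these compounds, compound 4 gave no number, leaving no step from compound 3 to compound 4 to read, and no outside measurement bears on this result. On these data alone, what methyl in place of hydrogen on an aromatic carbon does to the effect remains open.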